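Fluorine placement on the ring nitrogen aryl group

The compounds below may be only part of what the source reports. "The series", "measured", "known", "first", "only" and "open" are said of these compounds alone.

For the measured compounds named here, compound 2 `COc1cc(F)ccc1N1C(=O)CSC1c1cccc(C(=O)NCCCCc2ccccc2)c1` gives 81% in a functional assay on HOS cells (Homo sapiens) for inhibition, read by CCK-8 assay, with a stated time of 72 h, tested at 1 uM (a lower number here means less inhibition, a higher number more inhibition at the concentration tested (going by the name of the read-out)), the highest of the two numbers so far; its nearest neighbour is compound 1 `COc1ccc(C)cc1N1C(=O)CSC1c1cccc(C(=O)NCCCCc2ccccc2)c1`, which gives 42%. Going by the values given here, the only measured step, a number 39 percentage points higher from compound 1 to compound 2 (beyond the scatter), concerns a different exchange and bears on compound 3 `COc1c(F)cccc1N1C(=O)CSC1c1cccc(C(=O)NCCCCc2ccccc2)c1` only loosely. Compound 3 differs from compound 2 by 3-fluoro-2-methoxyphenyl in place of 4-fluoro-2-methoxyphenyl on an amide-type nitrogen in a ring, the same atoms joined differently. Among the compounds with values here, no measured step isolates this fluorine shift, so compound 3 is expected near compound 2 with a wide range; the estimated step is a number 16 percentage points lower from compound 2 to compound 3 (beyond the scatter). For compound 3 the expected value is 65%, within 35% to 90%.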

Compound 3, a percentage reported as inhibition, at one concentration (the size of the read-out at that concentration, not a potency): 9%
For compound 3 the middle estimate is 56 percentage points above the measured one; measured number outside the range, below it.
By their numbers in this assay, from the lowest: compound 3; then compound 1; then compound 2.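

In this assay the fluorine position alone carries a large effect: the exchange gives a number 72 percentage points lower from compound 2 to compound 3 (beyond the scatter) with the same atoms joined differently. The step of a number 33 percentage points lower from compound 1 to compound 3 (beyond the scatter) also places 3-fluoro-2-methoxyphenyl under 2-methoxy-5-methylphenyl at this place on the amide-type nitrogen. Nothing at hand accounts for these steps.

Open, going by these compounds, is how a plain 2-methoxyphenyl group or a 4-chloro-2-methoxyphenyl group would compare on the shared core. Also open, on these data alone, is whether this order of aryl groups holds with a shorter chain on the amide.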